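Triazole substituent swap in the butenolide series

This account rests on a few compounds, and the source may have more. Where it says the series, first, only, none or still open, it means among the compounds named here.

Working notes. In a functional assay on CFPAC-1 cells (Homo sapiens) for antiproliferative activity, read by MTT assay, with a stated time of 72 h (on this read-out higher numbers stand for weaker inhibition and lower numbers for stronger inhibition), compound 3 `O=C1O[C@H]([C@@H](O)Cn2cc(CNS(=O)(=O)c3ccc(F)cc3)nn2)C(OCc2ccccc2)=C1OCc1ccccc1` gives 34700 nM. Compound 1 `O=C1O[C@H]([C@@H](O)Cn2cc(-c3cc(F)cc(F)c3)nn2)C(OCc2ccccc2)=C1OCc1ccccc1` gives 62400 nM, and compound 2 `O=C1O[C@H]([C@@H](O)Cn2cc(CNS(=O)(=O)c3ccc(Cl)cc3F)nn2)C(OCc2ccccc2)=C1OCc1ccccc1` gives 58200 nM. Compound 3 thus carries the lowest of the three numbers, but a 1.8-fold lower number from compound 1 to compound 3 (0.25 log units; within the scatter) and a 1.7-fold lower number from compound 2 to compound 3 (0.22 log units; within the scatter) are both within the scatter, so no ordering among the three can be claimed.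

Compound 4 `Cc1ccc(-c2cn(C[C@H](O)[C@H]3OC(=O)C(OCc4ccccc4)=C3OCc3ccccc3)nn2)cc1` differs from compound 3 by 4-methylphenyl in place of (((4-fluorophenyl)sulfonyl)amino)methyl on an aromatic carbon. For the measured compounds named here, only one of the measured steps bears on this change: a 1.8-fold lower number from compound 1 to compound 3 (0.25 log units; within the scatter), in which a 3,5-difluorophenyl on the same aromatic carbon gave way to the (((4-fluorophenyl)sulfonyl)amino)methyl group. Compound 4 reverses that kind of exchange, putting a 4-methylphenyl in the place the 3,5-difluorophenyl of compound 1 occupied. Since that step stayed within the scatter, the expectation is that a 1.4-fold higher number from compound 3 to compound 4 (0.16 log units; within the scatter) also falls within the scatter, if anything drifting toward the number of compound 1. The step of a 1.7-fold lower number from compound 2 to compound 3 (0.22 log units; within the scatter) concerns only the group on the sulfonyl sulfur, which is absent in compound 4, and offers no further guidance. For compound 4 the estimate in this assay is 50000 nM, with a range from 20000 nM to 130000 nM.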

Compound 4, half-maximal inhibitory concentration: > 100000 nM
Compound 4 ended at the assay's limit (the forecaster's own chance of this, stated with the estimate: 10%); middle value at least 2.0-fold (0.30 log units) from the limit.
By their numbers in this assay, from the lowest: compounds 3, 2 and 1 (each within the scatter of the next). At a limit, above all of these: compound 4.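

In this assay compound 4 sits at a limit of the assay and has no exact number: the limit of > 100000 nM in this assay, at which 1 of the 4 values shown sits. Even so, exchanging (((4-fluorophenyl)sulfonyl)amino)methyl for 4-methylphenyl on this aromatic carbon of the five-membered aromatic ring with 3 nitrogen gives an at least 2.8-fold higher number from compound 3 to compound 4 (0.45 log units; beyond the scatter), the first step at this position to pass beyond the scatter, whereas a 1.8-fold lower number from compound 1 to compound 3 (0.25 log units; within the scatter) stayed within it. The other new step, an at least 1.6-fold higher number from compound 1 to compound 4 (0.20 log units; that floor lies within the scatter), gives only a floor, so 4-methylphenyl and 3,5-difluorophenyl cannot be ordered at this position, and the change shows only that this position can respond to the group it carries.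

The leaving and entering groups differ in the sulfonyl, the amino hydrogen, the methylene link and the ring substituent all at once, so the compounds shown do not tell which of these features goes with the step. As far as these compounds go, a 4-methylphenyl held on a longer chain, or a simple amine or carboxylic acid on the same aromatic carbon, would help to separate these features, and the true size of the step remains open while compound 4 stands at a limit.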